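The compounds below may be only part of what the source reports. "The series", "measured", "known", "first", "only" and "open" are said of these compounds alone.

Measured so far in a functional assay on RAW264.7 cells (Mus musculus) for inhibition, with stated times of 1 h and 24 h; on this read-out lower numbers stand for stronger inhibition and higher numbers for weaker inhibition:
- compound 1 `COc1ccc(C(=O)NCCCNc2cc(-c3cn(-c4ccccc4)nc3-c3cccc(OC)c3)ccn2)cc1`: 2940 nM
- compound 2 `COc1cccc(-c2nn(-c3ccccc3)cc2-c2ccnc(NCCNC(=O)Nc3cccc(C(F)(F)F)c3)c2)c1`: 5110 nM

Going by the values given here, compound 2, at 5110 nM, lies within the scatter of compound 1, at 2940 nM, so the two values set no order between these compounds. The next compound to be tested is compound 3 `COc1cccc(-c2nn(-c3ccccc3)cc2-c2ccnc(NCCNC(=O)Nc3ccc(Cl)c(Cl)c3)c2)c1`. It differs from compound 2 by 3,4-dichlorophenyl in place of 3-(trifluoromethyl)phenyl on an amide-type nitrogen, with 3,4-dichlorophenyl in place of 3-(trifluoromethyl)phenyl on an amide-type nitrogen. Among the compounds with values here, no measured pair isolates this change, so the expectation starts from compound 2 at 5110 nM and remains loose. The expected 1.3-fold lower number from compound 2 to compound 3 (0.11 log units; within the scatter) is small, and no shift beyond the scatter is anticipated in either direction in this assay. For compound 3, the estimated value is 4000 nM, with an expected range of 1500 nM to 10000 nM.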

Compound 3, half-maximal inhibitory concentration: 4510 nM
The estimate for compound 3 lay 1.1-fold (0.05 log units) below the measured number; low and high end bracket the measured number.
By their numbers in this assay, from the lowest: compounds 1, 3 and 2 (each within the scatter of the next).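

In this assay, 3,4-dichlorophenyl in place of 3-(trifluoromethyl)phenyl on the amide-type nitrogen gives a 1.1-fold lower number from compound 2 to compound 3 (0.05 log units; within the scatter) and so sets no order between these two groups at this position. The wider change on the saturated chain, ((3,4-dichlorophenyl)carbamoyl)amino in place of (((4-methoxyphenyl)carbonyl)amino)methyl, gives a 1.5-fold higher number from compound 1 to compound 3 (0.19 log units; within the scatter) and so also sets no order, which means that neither step separates the compounds on this read-out. No supporting data on these steps are available to interpret them further.

As far as these compounds go, whether a group of another kind on this nitrogen, such as a carboxylic acid or a primary amine in place of the substituted phenyl ring, would move the number beyond the scatter remains open. Also open, from the compounds shown here alone, is the effect of a longer chain with the 3,4-dichlorophenyl group kept.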